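A Methyl Added to an Inactive Propyl-Bearing Core

This account rests on a few compounds, and the source may have more. Where it says the series, first, only, none or still open, it means among the compounds named here.

Compound 1, `CCCc1ncn2c(O)nncc12`, was tested in a functional assay for inhibition, with Homo sapiens as the target; a higher number here means a weaker inhibitor, a lower number a stronger inhibitor. In this assay compound 1 gives only a limit, > 48000 nM. Compound 2, `CCCc1ncn2c(SC)nncc12`, differs from it by methylsulfanyl in place of hydroxy on an aromatic carbon. In this assay compound 2 likewise gives only a limit, > 48000 nM. The step that the two limits leave unreadable from compound 1 to compound 2 therefore cannot be read, because of the limit of > 48000 nM in this assay, at which 2 of the 2 values shown sit. Compound 1 thus stands at the limit, with no number to anchor it.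

Compound 3, `CCCc1nc(C)n2c(O)nncc12`, carries methyl in place of hydrogen on an aromatic carbon. The only measured step on this core is unreadable, so nothing shown points to a change in either direction, and no number is available to gauge the size of such a step. Compound 3 is expected to remain at or past the limit, estimated at 100000 nM with a range from 30000 nM to 500000 nM. The expected step that the limit leaves unreadable from compound 1 to compound 3 is accordingly estimated as no readable gain.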

Compound 3, half-maximal inhibitory concentration: > 48000 nM
Compound 3 was reported as a limit (the forecaster's own chance of this, stated with the estimate: 85%); the middle value lies beyond the limit too.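

In this assay compound 3 gives only a limit, > 48000 nM, so no step from compound 1 to compound 3 can be read: the limit of > 48000 nM in this assay, at which 3 of the 3 values shown sit.

The compounds shown leave open whether any change on the shared core yields a readable inhibitory concentration, and how far methyl or methylsulfanyl shifts it.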